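Fluorine removal on the vinyl sulfone in a cytotoxicity assay

A few compounds are considered here, and "the series" means these few. Any claim that something is new, unique, unknown or untested is made for them only; others in the source may bear on it.

Measured compounds:
compound 1, `O=C(NCc1ccccc1C(=O)N[C@H](/C=C/S(=O)(=O)Oc1ccccc1)CCc1ccccc1)c1ccncc1`: "nd" (no result reported)
compound 2, `O=C(NCc1ccccc1C(=O)N[C@H](/C=C(\F)S(=O)(=O)Oc1ccccc1)CCc1ccccc1)c1ccncc1`: > 100000 nM
compound 3, `O=C(NCc1ccccc1C(=O)N[C@H](/C=C(\F)S(=O)(=O)c1ccccc1)CCc1ccccc1)c1ccccc1`: 43000 nM

In a toxicity assay on J774.1 cells (Mus musculus) for cytotoxicity, read by MTT assay, with a stated time of 48 h (a lower number here means that less compound is tolerated, a higher number that more compound is tolerated), compound 1 has no reported result. For compound 2 the entry is a limit of the assay, > 100000 nM, not a number. Going by the values given here, compound 3 gives 43000 nM and is the only compound with a single number in this assay. One further value is the limit of > 100000 nM in this assay, at which 1 of the 3 values shown sits. Compound 4, `O=C(NCc1ccccc1C(=O)N[C@H](/C=C/S(=O)(=O)c1ccccc1)CCc1ccccc1)c1ccccc1`, differs from compound 3 by 2-(phenylsulfonyl)ethenyl in place of 2-fluoro-2-(phenylsulfonyl)ethenyl on a saturated chain carbon bound to an amide-type nitrogen and a saturated chain carbon. Among the compounds with values here, no measured pair shows this change, so no step size is known from the data. Compound 4 is expected to stay within the scatter of compound 3 in this assay, a step of a 1.2-fold higher number from compound 3 to compound 4 (0.07 log units; within the scatter), with an estimate of 50000 nM between 20000 nM and 150000 nM.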

Compound 4, half-maximal cytotoxic concentration: > 100000 nM
Compound 4: a limit, no number (the forecaster's own chance of this, stated with the estimate: 30%); middle value at least 2.0-fold (0.30 log units) from the limit.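

In this assay, going by these compounds alone, 2-(phenylsulfonyl)ethenyl in place of 2-fluoro-2-(phenylsulfonyl)ethenyl gives an at least 2.3-fold higher number from compound 3 to compound 4 (0.36 log units; beyond the scatter), the first step that can be read at this position. Among these two compounds, the fluorine-bearing group is therefore the less tolerated one. The entry for compound 4 is a limit of the assay and not a number, so the step has no upper end: the limit of > 100000 nM in this assay, at which 2 of the 4 values shown sit.

Compound 1 has no reported result, so it and compound 2 give no second reading of this change. As far as these compounds go, whether a chlorine or a methyl group in place of the fluorine would behave like either compound remains open.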